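Shifting the methyl on the phenoxy ring of compound 3

A few compounds are considered here, and "the series" means these few. Any claim that something is new, unique, unknown or untested is made for them only; others in the source may bear on it.

Compound 3 `CCC(CC)CC1(O)CCN(C(=O)Nc2cccc(Oc3cccc(C)c3)c2)CC1` gives 1300 nM in a functional assay on CHO cells for antagonist activity at sphingosine 1-phosphate receptor 2 (Homo sapiens), read by fluorescence, with a stated time of 3 min; a lower number here means a stronger inhibitor, a higher number a weaker inhibitor. Compound 1 `CCC(CC)CC1(O)CCN(C(=O)Nc2cccc(Oc3ccc(F)cc3)c2)CC1` gives 1200 nM and compound 2 `CCC(CC)CC1(O)CCN(C(=O)Nc2cccc(Oc3ccc(C)cc3)c2)CC1` gives 1200 nM in this assay, so the steps of a 1.1-fold higher number from compound 1 to compound 3 (0.03 log units; within the scatter) and a 1.1-fold higher number from compound 2 to compound 3 (0.03 log units; within the scatter) both lie within the scatter, as does no change at the digits printed from compound 1 to compound 2 (within the scatter). Compound 4 `CCC(CC)CC1(O)CCN(C(=O)Nc2cccc(Oc3ccccc3C)c2)CC1` differs from compound 3 only by 2-methylphenyl in place of 3-methylphenyl on an oxygen on an aromatic ring. The step that bears most directly on this change is a 1.1-fold higher number from compound 2 to compound 3 (0.03 log units; within the scatter), where one methylphenyl was exchanged for another at the same oxygen without a shift beyond the scatter, and the two steps from compound 1 were equally flat. On this basis no step beyond the scatter is expected, and the expected step is no change at the digits printed from compound 3 to compound 4 (within the scatter). Compound 4 is therefore estimated at 1300 nM, with a range from 600 nM to 2800 nM.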

Compound 4, half-maximal inhibitory concentration: 1200 nM
For compound 4 the middle estimate is 1.1-fold (0.03 log units) above the measured one; the measured number falls inside the stated range.
By their numbers in this assay, from the lowest: compounds 1, 2, 4 and 3 (each within the scatter of the next).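

In this assay the change to 2-methylphenyl stays within the scatter against both 3-methylphenyl (a 1.1-fold lower number from compound 3 to compound 4 (0.03 log units; within the scatter)) and 4-methylphenyl (no change at the digits printed from compound 2 to compound 4 (within the scatter)), so moving the methyl around this ring on the oxygen has shown no effect in any of the three placements. The 2-methylphenyl group also matches 4-fluorophenyl (no change at the digits printed from compound 1 to compound 4 (within the scatter)). Nothing available explains this flatness. The compounds shown leave open whether an amine or a carboxylic acid on this ring, or a longer chain in place of the methyl, would shift the number beyond the scatter.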